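This account rests on a few compounds, and the source may have more. Where it says the series, first, only, none or still open, it means among the compounds named here.

Measured so far:

Compound 1, `COCC1(C)Oc2ccc(C#N)cc2[C@@H](N=C(NC#N)c2cccnc2)[C@@H]1O`, in an ADME assay on the whole organism (blood) for pharmacokinetics, with Canis familiaris (Canis lupus familiaris) as the target (on this read-out higher numbers stand for a longer-lived compound and lower numbers for a shorter-lived compound), compound 1 gives 0.04 h.
Compound 2, `C=CCn1nc(N[C@@H]2c3cc(C#N)ccc3OC(COC)(COC)[C@H]2O)ccc1=O`, in this assay compound 2 gives 0.0483 h.

Both numbers are very small, and the two lie within the usual scatter of each other, so nothing can be said about which of the two compounds lasts longer. Compound 2 is the starting point for the next step.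

Compound 3, `CCCn1nc(N[C@@H]2c3cc(C#N)ccc3OC(COC)(COC)[C@H]2O)ccc1=O`, has not yet been measured. It differs from compound 2 in one place only: ethyl in place of vinyl on a saturated chain carbon bound to an aromatic nitrogen. A saturated chain replaces one that carried a double bond, and nothing else in the molecule changes. Given how little separates compound 1 and compound 2, a change this small is expected to leave the half-life of compound 3 close to that of compound 2, with a step of a 1.0-fold higher number from compound 2 to compound 3 (0.02 log units; within the scatter) that should stay within the scatter. Compound 3 is therefore estimated at 0.05 h, in a range from 0.025 h to 0.1 h.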

Compound 3, half-life: 0.0633 h
Compound 3: middle estimate off by 1.3-fold (0.10 log units), on the low side; the range from low to high includes it.
By their numbers in this assay, from the lowest: compounds 1, 2 and 3 (each within the scatter of the next).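

Swapping vinyl for ethyl on a saturated chain carbon bound to an aromatic nitrogen, which turns the allyl chain into a propyl chain, gives in this assay a 1.3-fold higher number from compound 2 to compound 3 (0.12 log units; within the scatter). Within the data shown here, this is the first pair that differs in one place only, and it shows that the double bond in this chain can go without a change that this read-out can tell apart from scatter, with compound 3 still at just 0.0633 h. No measurement at hand offers an explanation for how alike the two chains read.

As far as these compounds go, whether a longer chain, or a chain ending in an amine or a carboxylic acid, would move the half-life clearly at this place remains open. A single pair also cannot tell whether the same swap would read alike on another core.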